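Flipping One Ring Centre of a Histone Deacetylase Binder

This account rests on a few compounds, and the source may have more. Where it says the series, first, only, none or still open, it means among the compounds named here.

Compound 2 `O=C(NO)c1cccc(-c2cn([C@@H]3C[C@@H](CO)N(Cc4ccccc4)C3)nn2)c1` and compound 1 `O=C(NO)c1cccc(-c2cn([C@H]3C[C@H](CO)N(Cc4ccccc4)C3)nn2)c1` are mirror images: they share every atom and bond and differ only in configuration as drawn. In an assay on Sf9 cells for inhibition of histone deacetylase 11 (Homo sapiens), read by fluorescence, tested at 0.5 uM (on this read-out higher numbers stand for more inhibition at the one concentration tested (going by the name of the read-out) and lower numbers for less inhibition), compound 1 gives < 10%, which is a limit of the assay and not a number. In this assay compound 2 gives < 10%, again a limit rather than a number. The step that the two limits leave unreadable from compound 1 to compound 2 cannot be sized, because of the limit of < 10% in this assay, at which 2 of the 2 values shown sit. Compound 3 `O=C(NO)c1cccc(-c2cn([C@@H]3C[C@H](CO)N(Cc4ccccc4)C3)nn2)c1` is the next move from compound 2, and the change is the two compounds have the same atoms and bonds and differ only in configuration as drawn: 1 of 2 stereo elements differ; a stereocentre at a saturated ring carbon is drawn S in compound 2 and R in compound 3. Among the measured compounds shown here, only one measured step bears on such a change of configuration, and its size is hidden by the limits, so no shift beyond the scatter is expected from it. Compound 3 is expected to show a step that the limit leaves unreadable from compound 2 to compound 3 of little size. For compound 3 the estimated value is 8%, with a range from 0% to 20%.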

Compound 3, a percentage reported as inhibition, at one concentration (the size of the read-out at that concentration, not a potency): < 10%
Compound 3: only a limit was reported (the forecaster's own chance of this, stated with the estimate: 70%); the middle value does not contradict the limit.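

No step among compound 1, compound 2 and compound 3 can be read, because all three stop at the same assay limit rather than giving a number: the limit of < 10% in this assay, at which 3 of the 3 values shown sit.

The compounds shown leave open whether configuration at these two ring carbons makes any difference to inhibition in this assay.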